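The source may report more compounds than this note shows. Statements on the series, on what has been measured and on what is new or still open speak of the compounds shown alone.

Among the measured compounds shown here, compound 1 `CCCCCCOC(=O)NC(=O)Oc1c(C(C)C)cccc1C(C)C` stands second highest of the three numbers so far in an assay on microsomes from intestine for inhibition of acyl-CoA:cholesterol acyltransferase (Oryctolagus cuniculus) (a lower number here means a stronger inhibitor, a higher number a weaker inhibitor), where compound 1 gives 53 nM. Compound 2 `CCCCCCCCCCCCCCCCOC(=O)NC(=O)Oc1c(C(C)C)cccc1C(C)C` gives 50 nM, and compound 3 `CCCCCCCC(C)OC(=O)NC(=O)Oc1c(C(C)C)cccc1C(C)C` gives 97 nM. Both measured steps alter only the group on the oxygen next to the carbonyl group: a 1.1-fold lower number from compound 1 to compound 2 (0.03 log units; within the scatter) and a 1.8-fold higher number from compound 1 to compound 3 (0.26 log units; within the scatter). Compound 4 `CC(C)c1cccc(C(C)C)c1OC(=O)NC(=O)SC1CCCCC1` differs from compound 1 by cyclohexylsulfanyl in place of hexyloxy on a carbonyl carbon. Neither measured step exchanges that oxygen for sulfur or introduces a ring, so they bear on this change only loosely; both, however, stayed within the scatter, and a step of similar size is expected here, a 1.3-fold higher number from compound 1 to compound 4 (0.12 log units; within the scatter), with no direction favoured. Compound 4 is therefore estimated at 70 nM, between 25 nM and 200 nM.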

Compound 4, half-maximal inhibitory concentration: 97 nM
The estimate for compound 4 lay 1.4-fold (0.14 log units) below the measured number; measured number inside the range.
By their numbers in this assay, from the lowest: compounds 2, 1, 3 and 4 (each within the scatter of the next).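

In this assay, cyclohexylsulfanyl in place of hexyloxy on a carbonyl carbon gives a 1.8-fold higher number from compound 1 to compound 4 (0.26 log units; within the scatter), so a group with sulfur and a ring can sit at this position without a step beyond the scatter. The earlier steps shown here changed only carbon chains on the oxygen, and here sulfur and the ring enter together, so their separate contributions cannot be told apart. No measurement available explains this result. Cyclohexyloxy or hexylsulfanyl would separate the two, and whether an amine on this carbonyl carbon would also stay within the scatter remains open.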